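Swapping an ester chain for benzyl on compound 1

The source may report more compounds than this note shows. Statements on the series, on what has been measured and on what is new or still open speak of the compounds shown alone.

Compound 1, `CCOC(=O)C(C)C(O)(c1ccc(OC)c(OC)c1OC)c1cccc2ccccc12`, in a functional assay on MDA-MB-231 cells (Homo sapiens) for inhibition, read by sulforhodamine B assay, with a stated time of 48 h (on this read-out higher numbers stand for weaker inhibition and lower numbers for stronger inhibition), shows only the assay limit > 20000 nM.
Compound 2, `COc1ccc(C(c2ccccc2O)c2cccc3ccccc23)c(OC)c1OC`, gives 17700 nM in this assay.
Compound 3, `COc1ccc(/C(=N/OC(C)=O)c2cccc3ccccc23)c(OC)c1OC`, gives 17000 nM in this assay.

Compound 1 stands at the limit of > 20000 nM in this assay, at which 1 of the 3 values shown sits, so no number is known for it, and the two numbered compounds sit not far from that limit. Compound 4, `COc1ccc(C(O)(Cc2ccccc2)c2cccc3ccccc23)c(OC)c1OC`, differs from compound 1 in one place: benzyl in place of 1-(ethoxycarbonyl)ethyl on a saturated chain carbon bound to two aromatic carbons and an oxygen on a saturated carbon. For the measured compounds named here, no measured pair isolates this change, so any expectation rests on the three measured compounds alone, all of which show weak inhibition in this assay. The account therefore expects the step of an at least 1.1-fold lower number from compound 1 to compound 4 (0.04 log units; that floor lies within the scatter) to be small, with no clear direction beyond the usual scatter, and with a real chance that compound 4 also returns only a limit. Compound 4 is expected to give about 18000 nM in this assay, within a range from 8000 nM to 40000 nM.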

Compound 4, half-maximal inhibitory concentration: 4780 nM
For compound 4 the middle estimate is 3.8-fold (0.58 log units) above the measured one; the whole stated range lies above it.
By their numbers in this assay, from the lowest: compound 4; then compounds 3 and 2 (each within the scatter of the next). At a limit, above all of these: compound 1.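

Benzyl in place of 1-(ethoxycarbonyl)ethyl gives an at least 4.1-fold lower number from compound 1 to compound 4 (0.62 log units; beyond the scatter) in this assay. For the compounds shown here, this shows that a change on a saturated chain carbon bound to two aromatic carbons and an oxygen on a saturated carbon can move the number beyond the scatter, which the earlier compounds, with no step between them, could not show. The step is only a floor, and the full size of the change stays unknown, because compound 1 gives a limit and not a number: the limit of > 20000 nM in this assay, at which 1 of the 4 values shown sits.

This single swap removes the ester and brings in the aromatic ring together, and the compounds shown do not separate the two. On these data alone, how a carboxylic acid in place of the ethyl ester, or a longer chain ending in phenyl, would read at this place remains open.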